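This account rests on a few compounds, and the source may have more. Where it says the series, first, only, none or still open, it means among the compounds named here.

In a functional assay on HCT-116 cells (Homo sapiens) for inhibition, read by MTT assay, with a stated time of 72 h (a higher number here means a weaker inhibitor of growth, a lower number a stronger inhibitor of growth), compound 3 `CNC(=O)/C=C/c1ccncc1-c1ccc2[nH]ccc2c1` gives > 30000 nM, a limit rather than a number, and so stands at the limit of > 30000 nM in this assay, at which 1 of the 3 values shown sits. Compound 4 `O=C(O)/C=C/c1ccncc1-c1ccc2[nH]ccc2c1` puts hydroxy in place of methylamino on a carbonyl carbon. Compound 1 `CCOC(=O)/C=C/c1ccncc1-c1ccc2[nH]ccc2c1`, which has ethoxy on that carbon, gives 4830 nM. Among the compounds with values here, the one measured step at this carbon is an at least 6.2-fold higher number from compound 1 to compound 3 (0.79 log units; beyond the scatter). Differing from compound 4 in the core as well, compound 2 `Cn1ccc2cc(-c3cnccc3/C=C/C(=O)O)ccc21` carries hydroxy there and gives 7260 nM. With that value as the closest guide, a lower number and thus stronger growth inhibition is expected, with the expected size being an at least 3.3-fold lower number from compound 3 to compound 4 (0.52 log units; beyond the scatter). The estimate for compound 4 is 9000 nM, with an expected range of 3500 nM to 28000 nM.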

Compound 4, concentration for 50% growth inhibition: > 30000 nM
Compound 4: only a limit was reported (the forecaster's own chance of this, stated with the estimate: 20%); middle value at least 3.3-fold (0.52 log units) from the limit.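

Compound 4 gives only a limit, and the step between compound 3 and compound 4 cannot be read. Even so, hydroxy, like methylamino, falls short of ethoxy on this carbonyl carbon, with hydrogen in place of ethyl giving an at least 6.2-fold higher number from compound 1 to compound 4 (0.79 log units; beyond the scatter). With hydroxy on that carbon, the methyl on the aromatic nitrogen also counts, as hydrogen in its place gives an at least 4.1-fold higher number from compound 2 to compound 4 (0.61 log units; beyond the scatter).

Any real gap between compound 3 and compound 4 stays hidden, with both at the same limit: the limit of > 30000 nM in this assay, at which 2 of the 4 values shown sit. On these data alone, how a propoxy or dimethylamino group would behave on that carbon remains open.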